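The source may report more compounds than this note shows. Statements on the series, on what has been measured and on what is new or still open speak of the compounds shown alone.

In a functional assay on G-361 cells (Homo sapiens) for cytotoxicity, read by fluorescence, with a stated time of 72 h (a lower number here means a stronger inhibitor, a higher number a weaker inhibitor), compound 1 (`CC(C)c1n[nH]c2c(NCc3ccc(-c4ccccn4)cc3)nc(NCCO)nc12`) gives 39 nM and compound 2 (`CC(C)c1n[nH]c2c(NCc3ccc(-c4ccccn4)cc3)nc(NCC(N)CO)nc12`) gives 1020 nM, so compound 2 holds the higher of the two numbers. Compound 3 (`CC(C)c1n[nH]c2c(NCc3ccc(-c4ccccn4)cc3)nc(NCCN(C)C)nc12`) has not yet been measured. The change from compound 2 is (dimethylamino)methyl in place of 1-amino-2-hydroxyethyl on a saturated chain carbon bound to a nitrogen on an aromatic ring. Among the measured compounds shown here, one measured step bears on it: a 26-fold higher number from compound 1 to compound 2 (1.42 log units; beyond the scatter), which put 1-amino-2-hydroxyethyl in place of hydroxymethyl. For the measured compounds named here, compound 3 no longer carries that group, but no measured compound carries (dimethylamino)methyl, so this step is only a partial guide. A moderate to large move toward a lower number is therefore expected, with the expected step being a 6.0-fold lower number from compound 2 to compound 3 (0.78 log units; beyond the scatter). Compound 3 is estimated at 170 nM, with an expected range from 45 nM to 650 nM.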

Compound 3, half-maximal inhibitory concentration: 640 nM
Compound 3: middle estimate off by 3.8-fold (0.58 log units), on the low side, within the range that was stated.
By their numbers in this assay, from the lowest: compound 1; then compounds 3 and 2 (each within the scatter of the next).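

In this assay, (dimethylamino)methyl in place of 1-amino-2-hydroxyethyl gives a 1.6-fold lower number from compound 2 to compound 3 (0.20 log units; within the scatter), so these two side chains are not separated, even though the entering group has 0 hydrogen-bond donors and the leaving group has 2. Against compound 1, dimethylamino in place of hydroxy on the chain gives a 16-fold higher number from compound 1 to compound 3 (1.22 log units; beyond the scatter), so the large gap first seen with compound 2 also appears with a chain that carries no hydroxy group; among these three compounds, the two with an amino group on the chain both stand well above compound 1. No evidence shown accounts for these differences.

Still open, as far as these compounds go, is whether the amine itself sets this gap or any replacement of the hydroxy of compound 1 does. A methyl ether in place of that hydroxy, or a longer chain ending in hydroxy, would bear on this.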